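A few compounds are considered here, and "the series" means these few. Any claim that something is new, unique, unknown or untested is made for them only; others in the source may bear on it.

Measured compounds:
- compound 1 `Cc1cc(C)c(NC(=O)N(Cc2cccc(-c3nn[nH]n3)c2)C2CCCCCC2)c(C)c1`: in an assay on microsomes from intestine for inhibition of acyl-CoA:cholesterol acyltransferase (Oryctolagus cuniculus) (on this read-out lower numbers stand for stronger inhibition and higher numbers for weaker inhibition), compound 1 gives > 1000 nM. This value is a limit of the assay, not a number.
- compound 2 `Cc1cc(C)c(NC(=O)N(Cc2cccc(-c3ccnn3C)c2)C2CCCCCC2)c(C)c1`: in this assay compound 2 gives 35 nM.

Going by the values given here, compound 2 therefore holds the only number recorded in this assay; the other entry is a limit (the limit of > 1000 nM in this assay, at which 1 of the 2 values shown sits). Among the compounds with values here, the single measured step, an at least 28-fold lower number from compound 1 to compound 2 (1.45 log units; beyond the scatter), exchanges one azole for another and is large.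

Compound 3 `Cc1cc(C)c(NC(=O)N(Cc2cccc(-c3cnn(C)c3)c2)C2CCCCCC2)c(C)c1` differs from compound 2 by 1-methyl-1H-pyrazol-4-yl in place of 1-methyl-1H-pyrazol-5-yl on an aromatic carbon. Within the data shown here, no measured step concerns a shift of the attachment point within the same methylated pyrazole, so the measured step gives no direct guidance; without such a precedent a step within the scatter is expected in this assay, with the estimated change a 1.4-fold higher number from compound 2 to compound 3 (0.15 log units; within the scatter). Compound 3 is accordingly estimated at 50 nM, with a range from 15 nM to 250 nM.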

Compound 3, half-maximal inhibitory concentration: 44 nM
Estimate against measurement, compound 3: 1.1-fold (0.06 log units) above, within the range that was stated.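

In this assay, moving the attachment point from 1-methyl-1H-pyrazol-5-yl to 1-methyl-1H-pyrazol-4-yl gives a 1.3-fold higher number from compound 2 to compound 3 (0.10 log units; within the scatter), so the two isomers cannot be told apart at this position. The large step away from the tetrazole is therefore not tied to one attachment point: the 2H-tetrazol-5-yl to 1-methyl-1H-pyrazol-4-yl exchange gives an at least 22-fold lower number from compound 1 to compound 3 (1.35 log units; beyond the scatter), which matches the size of an at least 28-fold lower number from compound 1 to compound 2 (1.45 log units; beyond the scatter). Both of these larger steps start from compound 1, whose entry is a limit of the assay and not a number: the limit of > 1000 nM in this assay, at which 1 of the 3 values shown sits.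

The compounds shown leave open whether the lower numbers depend on the methyl group on the pyrazole or on the pyrazole ring itself. Also open, on these data alone, is whether an unmethylated pyrazole, a phenyl or a carboxylic acid on the same aromatic carbon would track with compound 2 and compound 3 or with compound 1.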